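The compounds below may be only part of what the source reports. "The series", "measured", "known", "first", "only" and "open" are said of these compounds alone.

Measured compounds:
compound 1 `COc1cc(Cl)cc(-c2nn(-c3cccc(NC(=O)Nc4cccc(C(F)(F)F)c4)c3)cc2-c2ccncc2)c1` gives 5.3% in a functional assay on SK-MEL-5 cells (Homo sapiens) for inhibition, read by sulforhodamine B assay, with a stated time of 48 h, tested at 10 uM; on this read-out lower numbers stand for a stronger effect and higher numbers for a weaker effect at the one concentration tested;
compound 2 `COc1cc(Cl)cc(-c2nn(-c3cccc(NC(=O)Nc4ccc(Cl)c(C(F)(F)F)c4)c3)cc2-c2ccncc2)c1` gives -71.2% in this assay;
compound 3 `COc1cc(Cl)cc(-c2nn(-c3cccc(NC(=O)c4cc(C(F)(F)F)cc(C(F)(F)F)c4)c3)cc2-c2ccncc2)c1` gives 67.3% in this assay.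

Compound 2 stands lowest of the three numbers, and so shows the strongest effect among them: compound 1 lies nearest, beyond the scatter, and compound 3 furthest, also beyond the scatter. Among the measured compounds shown here, the only single-place step among the measured compounds, a number 76.5 percentage points lower from compound 1 to compound 2 (beyond the scatter), runs inside the urea series and concerns a chloro on the outer aromatic ring; it does not touch the carbonyl carbon itself.

Compound 4 `COc1cc(Cl)cc(-c2nn(-c3cccc(NC(=O)c4ccc(Cl)c(Cl)c4)c3)cc2-c2ccncc2)c1` is not yet measured. It differs from compound 2 as follows: 3,4-dichlorophenyl in place of (4-chloro-3-(trifluoromethyl)phenyl)amino on a carbonyl carbon. For the measured compounds named here, no measured step covers this exchange of an amino-bearing group for a directly attached aryl on the carbonyl. Going by the values given here, compound 3, the one measured compound whose carbonyl also carries an aryl directly, differs from compound 2 in more than one place, so only its value can be compared: compound 3 gives 67.3%, far weaker than compound 2. Because compound 3 gives 67.3%, a weakening step is expected, a number 106.2 percentage points higher from compound 2 to compound 4 (beyond the scatter), though its size is uncertain. Compound 4 is therefore estimated at 35%, within -15% to 80%.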

Compound 4, a percentage reported as activity, at one concentration (the size of the read-out at that concentration, not a potency): 78.5%
For compound 4 the middle estimate is 43.5 percentage points below the measured one; low and high end bracket the measured number.
By their numbers in this assay, from the lowest: compound 2; then compound 1; then compound 3; then compound 4.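

In this assay the exchange of (4-chloro-3-(trifluoromethyl)phenyl)amino for 3,4-dichlorophenyl on the carbonyl carbon gives a number 149.7 percentage points higher from compound 2 to compound 4 (beyond the scatter) and so removes the strong effect seen for compound 2 at the one concentration tested. The matching exchange of (3-(trifluoromethyl)phenyl)amino gives a number 73.2 percentage points higher from compound 1 to compound 4 (beyond the scatter), so both measured ureas lose effect when a directly attached aryl takes the place of the amino-bearing group on this carbonyl carbon. No measured evidence explains these steps.

The compounds shown leave open how much of each step comes from losing the amino nitrogen and how much from changing the ring's substituents. They also leave open how a methylene linker in place of that nitrogen would read in this assay.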